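The compounds below may be only part of what the source reports. "The series", "measured", "known", "first", "only" and "open" are said of these compounds alone.

Compound 2 `CCC(CC)(c1ccc(OCCCCO)c(C)c1)c1ccc(OCC(O)C(C)(C)C)c(OCC(O)C(C)(C)C)c1` and compound 1 `CCC(CC)(c1ccc(OCC(O)CO)c(C)c1)c1ccc(OCC(O)C(C)(C)C)c(OCC(O)C(C)(C)C)c1` share one core. In an assay on cells for binding affinity to vitamin D3 receptor (Homo sapiens), read by fluorescence, tested at 1 uM (on this read-out higher numbers stand for more inhibition at the one concentration tested (going by the name of the read-out) and lower numbers for less inhibition), compound 1 gives 78%, and compound 2 gives 71%, the lowest of the two numbers shown; the change a number 7 percentage points lower from compound 1 to compound 2 (within the scatter) stays within the scatter. Compound 3 `CCC(CC)(c1ccc(OCCCCCCO)c(C)c1)c1ccc(OCC(O)C(C)(C)C)c(OCC(O)C(C)(C)C)c1` differs from compound 2 by 2-hydroxyethyl in place of hydroxy on a saturated chain carbon, four bonds along the chain from an oxygen on an aromatic ring. Among the compounds with values here, only the step from compound 1 to compound 2 bears on this chain lengthening, and it did not exceed the scatter, so for compound 3 a step of a number 4 percentage points lower from compound 2 to compound 3 (within the scatter) is expected, with no change beyond the scatter. Compound 3 is therefore estimated at 67%, between 50% and 82%.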

Compound 3, a percentage reported as inhibition, at one concentration (the size of the read-out at that concentration, not a potency): 52%
For compound 3 the middle estimate is 15 percentage points above the measured one, within the range that was stated.
By their numbers in this assay, from the lowest: compound 3; then compounds 2 and 1 (each within the scatter of the next).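

Within the data shown here, with the longer chain, this position shows a change beyond the scatter for the first time: 2-hydroxyethyl in place of hydroxy gives a number 19 percentage points lower from compound 2 to compound 3 (beyond the scatter). Measured against the diol chain, 5-hydroxypentyl in place of 1,2-dihydroxyethyl gives a number 26 percentage points lower from compound 1 to compound 3 (beyond the scatter). Nothing measured here accounts for either step. The compounds shown leave open whether a chain ending in an amine or a carboxylic acid instead of hydroxy would give a similar number. They also leave open whether a longer chain, such as 7-hydroxyheptyl, would lower it further.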